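The compounds below may be only part of what the source reports. "The series", "measured", "known", "first", "only" and "open" are said of these compounds alone.

Going by the values given here, compound 2 `CC1(C)CCC(CN2CCN(c3ccc(C(=O)NS(=O)(=O)c4ccc(OCC5CCOC5)c([N+](=O)[O-])c4)c(Oc4cnc5[nH]ccc5c4)c3)CC2)=C(c2ccc(C(F)(F)F)cc2)C1` gives 4.4 nM in an assay on isolated protein for displacement of a labelled ligand from Apoptosis regulator Bcl-2 (Homo sapiens), with a stated time of 15 min (a higher number here means a weaker inhibitor, a lower number a stronger inhibitor), the higher of the two numbers measured so far. Among the compounds with values here, compound 1 `CN(C)CCCNc1ccc(S(=O)(=O)NC(=O)c2ccc(N3CCN(CC4=C(c5ccc(C(F)(F)F)cc5)CC(C)(C)CC4)CC3)cc2Oc2cnc3[nH]ccc3c2)cc1[N+](=O)[O-]` gives 0.89 nM in this assay, and the only measured step is a 4.9-fold higher number from compound 1 to compound 2 (0.69 log units; beyond the scatter). Compound 3 `CC1(C)CCC(CN2CCN(c3ccc(C(=O)NS(=O)(=O)c4ccc(OCC5CCSCC5)c([N+](=O)[O-])c4)c(Oc4cnc5[nH]ccc5c4)c3)CC2)=C(c2ccc(C(F)(F)F)cc2)C1` has not yet been measured; it differs from compound 2 by thian-4-yl in place of oxolan-3-yl on a saturated chain carbon bound to an oxygen on an aromatic ring. Within the data shown here, the one measured step bears on this only loosely: it exchanged the whole group attached to the oxygen on the aromatic ring, whereas here only the ring at the end of the same chain changes, and no measured pair tracks an exchange of that sort. With nothing to point to a shift beyond the scatter, compound 3 is expected to sit near compound 2, the estimated step being a 1.0-fold higher number from compound 2 to compound 3 (0.01 log units; within the scatter). Compound 3 is accordingly estimated at 4.5 nM in this assay, with a range of 1.5 nM to 14 nM.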

Compound 3, half-maximal inhibitory concentration: 1.65 nM
Compound 3: the middle estimate sits 2.7-fold (0.44 log units) above what was measured, and the stated range covers the measured number.
By their numbers in this assay, from the lowest: compounds 1 and 3 (each within the scatter of the next); then compound 2.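

On a saturated chain carbon bound to an oxygen on an aromatic ring, exchanging only the terminal ring registers in this assay: thian-4-yl in place of oxolan-3-yl gives a 2.7-fold lower number from compound 2 to compound 3 (0.43 log units; beyond the scatter). The larger exchange on the aromatic carbon now stays within the scatter, with a 1.9-fold higher number from compound 1 to compound 3 (0.27 log units; within the scatter), so among these compounds the (3-(dimethylamino)propyl)amino group is not needed for a number in this range. No supporting measurement accounts for the shift produced by the ring exchange.

Thian-4-yl differs from oxolan-3-yl in both ring size and hetero atom, so the two changes remain unseparated here; oxan-4-yl and thiolan-3-yl would each change only one of them. As far as these compounds go, whether a ring nitrogen, as in piperidin-4-yl, fits at this position also remains open.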